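Swapping the aryl group on a urea-hydrazone: cytotoxicity estimate

The source may hold more compounds than are shown below. What is called first, only, known or untested is meant among the compounds shown, and "the series" means these compounds.

Measured compounds:
- compound 1 `COc1ccc(OC)c(/C=N/NC(=O)Nc2ccc(Oc3ccnc(-c4nncn4CCN(C)C)c3)c(F)c2)c1`: "not determined" (no result reported) in an ADME assay on WI-38 cells (Homo sapiens) for cytotoxicity, read by MTT assay, with a stated time of 72 h; on this read-out higher numbers stand for weaker inhibition and lower numbers for stronger inhibition
- compound 2 `CN(C)CCn1cnnc1-c1cc(Oc2ccc(NC(=O)N/N=C/c3cccc(Cl)c3Cl)cc2F)ccn1`: 6130 nM
- compound 3 `CN(C)CCn1cnnc1-c1cc(Oc2ccc(NC(=O)N/N=C/c3ccc(O)c(F)c3)cc2F)ccn1`: "not determined" (no result reported) in this assay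

All three share the same core, differing only in the aromatic group attached to the carbon that carries a double bond to nitrogen. For compound 1 this assay gave no number, so its standing cannot be placed; only compound 2 has a value, and that value is the sole anchor here. Compound 3 is likewise without a number.

Compound 4 `CN(C)CCn1cnnc1-c1cc(Oc2ccc(NC(=O)N/N=C/c3ccc(O)c(Br)c3)cc2F)ccn1` is the compound to be measured. It differs from compound 1 in one place: 3-bromo-4-hydroxyphenyl in place of 2,5-dimethoxyphenyl on a carbon with a double bond to nitrogen. Among the compounds with values here, no measured pair shows this exact change, and compound 1 itself carries no value, so no step can be computed. The expectation for this assay therefore rests on compound 2 alone, whose value of 6130 nM suggests that this family is only weakly toxic to these cells; a change of aryl group is not expected to move the number beyond the usual scatter.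

Compound 4 is expected to give about 6000 nM, estimated to lie between 2000 nM and 20000 nM.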

Compound 4, half-maximal inhibitory concentration: 5560 nM
Estimate against measurement, compound 4: 1.1-fold (0.03 log units) above; measured number inside the range.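

Within the data shown here, compound 2 and compound 4 differ in one place, so this pair gives the first step that can be read in this assay: replacing 2,3-dichlorophenyl with 3-bromo-4-hydroxyphenyl on a carbon with a double bond to nitrogen gives a 1.1-fold lower number from compound 2 to compound 4 (0.04 log units; within the scatter) for this pair. A single value could not show whether this place responds to a change of aryl group, but here a ring bearing chlorine and a ring bearing bromine and hydroxyl give values that cannot be told apart, even though the entering group has a hydrogen-bond donor and the leaving group does not. Nothing available explains this lack of separation.

Steps involving compound 1 and compound 3 cannot be read, as neither has a number, so the 2,5-dimethoxyphenyl group and the fluorine-bearing hydroxyphenyl group of those compounds remain unplaced. Among these compounds, also open is whether this flat response would hold for a ring carrying an amine or a carboxylic acid, or for a cyclohexyl group in place of the aromatic ring, since one pair shows only one change.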